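A few compounds are considered here, and "the series" means these few. Any claim that something is new, unique, unknown or untested is made for them only; others in the source may bear on it.

Working notes on the series. For the measured compounds named here, in a functional assay on A549 cells (Homo sapiens) for cytotoxicity, read by CellTiter-Blue, with a stated time of 72 h (on this read-out higher numbers stand for weaker inhibition and lower numbers for stronger inhibition), compound 1 `C/C=C(\C)[C@H]1OC(=O)[C@@H](C)NC(=O)[C@H]([C@@H](C)CC)NC(=O)CN(C)C(=O)[C@@H](Cc2ccccc2)N(C)C(=O)[C@H](C)NC(=O)[C@@H](CC(C)C)OC(=O)/C(C)=C/C[C@H](OCSC)[C@@H]1C` gives 0.00019 nM, the lower of the two numbers so far and far beyond the scatter from compound 2 `C/C=C(\C)[C@@H](O)[C@@H](C)[C@@H]1C/C=C(\C)C(=O)O[C@H](CC(C)C)C(=O)N[C@H](C)C(=O)N(C)[C@H](Cc2ccccc2)C(=O)N(C)CC(=O)N[C@@H]([C@@H](C)CC)C(=O)N[C@H](C)C(=O)O1`, which gives 1080 nM. Compound 3 `C/C=C(\C)[C@H]1OC(=O)[C@@H](C)NC(=O)[C@H]([C@@H](C)CC)NC(=O)CN(C)C(=O)[C@@H](Cc2ccccc2)N(C)C(=O)[C@@H](C)NC(=O)[C@@H](CC(C)C)OC(=O)/C(C)=C/C[C@H](OCSC)[C@@H]1C` has the same atoms and bonds as compound 1, and the two differ only in configuration as drawn: the two compounds have the same atoms and bonds and differ only in configuration as drawn: 1 of 11 stereo elements differ; a stereocentre at a saturated ring carbon is drawn S in compound 1 and R in compound 3. Going by the values given here, no measured pair differs in one place, so the data offer no direct precedent for this inversion. A move towards weaker inhibition in this assay, beyond the scatter, is nevertheless expected, though its size is poorly constrained. The estimated change is a 110-fold higher number from compound 1 to compound 3 (2.02 log units; beyond the scatter). For compound 3 the expected value is 0.02 nM, with an estimated range of 0.0005 nM to 2 nM.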

Compound 3, half-maximal inhibitory concentration: 4340 nM
Beside the measured number, compound 3's estimate is 220000-fold (5.34 log units) below it; the whole stated range lies below it.
By their numbers in this assay, from the lowest: compound 1; then compound 2; then compound 3.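

This position is far from tolerant: with every atom and bond kept, drawing one stereocentre at a saturated ring carbon R rather than S gives a 23000000-fold higher number from compound 1 to compound 3 (7.36 log units; beyond the scatter) in this assay. The earlier compounds shown here held no pair differing in one place, so this step is the only direct measure of what a single configuration is worth. The step can be assigned to this inversion alone because of one fact: the fact that compounds 1 and 3 differ only in the configuration as drawn.

The compounds shown leave open whether a longer chain or an amine at this stereocentre, drawn S, would hold the value of compound 1 0.00019 nM. They also leave open whether inverting any of the other stereo elements carries a step of similar size, and they say nothing on why this one does.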